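Thiosemicarbazone series: a bromophenyl replacement on an inactive pair

This account rests on a few compounds, and the source may have more. Where it says the series, first, only, none or still open, it means among the compounds named here.

Compound 1 `Cc1ccc(O)c(/C=N/NC(=S)N/N=C2\C(=O)Nc3ccc(C)cc32)c1` gives in a functional assay on HeLa cells (Homo sapiens) for inhibition, read by MTT assay (on this read-out higher numbers stand for weaker inhibition and lower numbers for stronger inhibition), only a limit, > 50000 nM. Its standing on the numbers shown is the limit of > 50000 nM in this assay, at which 2 of the 2 values shown sit, so no ordering among the measured compounds can be made. Compound 2 `Cc1ccc2c(c1)/C(=N/NC(=S)N/N=C/c1ccc3ccccc3c1)C(=O)N2` likewise reaches in this assay only a limit, > 50000 nM. Compound 3 `Cc1ccc2c(c1)/C(=N/NC(=S)N/N=C/c1ccc(Br)cc1)C(=O)N2` carries 4-bromophenyl in place of 2-hydroxy-5-methylphenyl on a carbon with a double bond to nitrogen. For the measured compounds named here, no step between measured compounds is available for this change. The expected step is a number no higher from compound 1 to compound 3 (the limit leaves the size open), that is none beyond the usual scatter, and most probably again a limit rather than a number. Compound 3 is therefore estimated at 50000 nM, within 20000 nM to 200000 nM.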

Compound 3, half-maximal inhibitory concentration: > 50000 nM
Compound 3: only a limit was reported; the forecaster's own chance of this, stated with the estimate: 80%; the middle value sits exactly at the limit.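

In this assay compound 3 gives > 50000 nM, again a limit, so no step from compound 1 to compound 3 can be read: the limit of > 50000 nM in this assay, at which 3 of the 3 values shown sit.

The compounds shown leave open which group, if any, would give a number rather than a limit.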